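Replacing Methoxy with Phenyl in a Level Series

The source may report more compounds than this note shows. Statements on the series, on what has been measured and on what is new or still open speak of the compounds shown alone.

In a functional assay on A549 cells (Homo sapiens) for antiproliferative activity, read by sulforhodamine B assay, with a stated time of 72 h (a lower number here means a stronger inhibitor, a higher number a weaker inhibitor), compound 1 (`COc1ccc(/C=C2\CCC=CC2=O)cc1`) gives 1460 nM and compound 2 (`COc1ccc(/C=C2\CCC=CC2=O)c(C)c1`) gives 1550 nM while compound 3 (`COc1ccc(/C=C2\CCC=CC2=O)cc1[N+](=O)[O-]`) gives 1480 nM in the same test. Compound 1 therefore stands level with both of the others, and all three lie within the usual scatter of such measurements.

Compound 4 (`O=C1C=CCC/C1=C\c1ccc(-c2ccccc2)cc1`) has not been measured yet. It carries phenyl in place of methoxy on an aromatic carbon. Two measured steps offer some guidance. Methyl in place of hydrogen gives a 1.1-fold higher number from compound 1 to compound 2 (0.03 log units; within the scatter) and nitro in place of hydrogen gives a 1.0-fold higher number from compound 1 to compound 3 (0.01 log units; within the scatter) as the second step. Among the compounds with values here, both of these changes keep the methoxy, so no measured compound shows what replacing it does, and the guidance is loose. Going by those two small steps, no change beyond the scatter is expected in this assay but the uncertainty is wide. The estimated step is a 1.2-fold higher number from compound 1 to compound 4 (0.07 log units; within the scatter) and this is a small one. In this assay compound 4 is estimated at 1700 nM with 700 nM to 4000 nM as its expected range.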

Compound 4, half-maximal inhibitory concentration: 3670 nM
For compound 4 the middle estimate is 2.2-fold (0.33 log units) below the measured one; low and high end bracket the measured number.
By their numbers in this assay, from the lowest: compounds 1, 3 and 2 (each within the scatter of the next); then compound 4.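

In this assay, phenyl in place of methoxy gives a 2.5-fold higher number from compound 1 to compound 4 (0.40 log units; beyond the scatter), the only listed step in this series that goes beyond the scatter. Within the data shown here, the earlier compounds kept the methoxy, so this is the first sign that the number responds to what sits at this place, although the step is modest and compound 4 is the weaker inhibitor of the pair. Nothing here explains the shift, and no supporting measurement bears on it.

The change removes methoxy and adds a six-membered aromatic ring in one move, so the loss of the first cannot be separated from the arrival of the second. Going by these compounds, whether a hydroxyl, an amine or a short alkyl chain at this place would stay level with compound 1 or also give a higher number remains open.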